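Pyridinyl to Cyanobenzyl on the Triazole Nitrogen

A few compounds are considered here, and "the series" means these few. Any claim that something is new, unique, unknown or untested is made for them only; others in the source may bear on it.

For the measured compounds named here, in a functional assay on SGC-7901 cells (Homo sapiens) for inhibition, read by MTT assay, with a stated time of 72 h (a higher number here means a weaker inhibitor of growth, a lower number a stronger inhibitor of growth), compound 2 `O[C@H](COCCOC[C@@H](O)Cc1cn(-c2cccnc2)nn1)Cc1ccc(-c2ccccc2)cc1` gives 29800 nM, the highest of the two numbers so far; compound 1 `O=C1COc2ccc(-n3cc(C[C@H](O)COCCOC[C@@H](O)Cc4ccc(-c5ccccc5)cc4)nn3)cc2N1` gives 15200 nM, and a 2.0-fold higher number from compound 1 to compound 2 (0.29 log units; within the scatter) lies within the scatter. Compound 3 `N#Cc1ccc(Cn2cc(C[C@H](O)COCCOC[C@@H](O)Cc3ccc(-c4ccccc4)cc3)nn2)cc1` carries 4-cyanobenzyl in place of pyridin-3-yl on an aromatic nitrogen, the same aromatic nitrogen of the shared core that changed between compound 1 and compound 2. That single earlier step at this position stayed within the scatter, so no shift beyond the scatter is expected in this assay for compound 3. The estimate for compound 3 is 22000 nM, with a range from 8000 nM to 60000 nM. This corresponds to an expected 1.4-fold lower number from compound 2 to compound 3 (0.13 log units; within the scatter).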

Compound 3, concentration for 50% growth inhibition: 7700 nM
The estimate for compound 3 lay 2.9-fold (0.46 log units) above the measured number, and the stated range ends above it.
By their numbers in this assay, from the lowest: compounds 3, 1 and 2 (each within the scatter of the next, the first and the last beyond it).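

In this assay the aromatic nitrogen of the triazole now shows a step beyond the scatter, a 3.9-fold lower number from compound 2 to compound 3 (0.59 log units; beyond the scatter) as 4-cyanobenzyl replaces pyridin-3-yl, so this position is not silent in this assay. Against the larger group of compound 1 the same position gives a 2.0-fold lower number from compound 1 to compound 3 (0.30 log units; within the scatter) and stays within the scatter. Nothing measured here accounts for the step.

The compounds shown leave open whether the nitrile or the benzyl link matters, since a plain benzyl group on that nitrogen would separate the two. Going by these compounds, what an amine or a carboxylic acid on the benzyl ring would give also stays open.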